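Two Methoxy Groups Give Way to a Single Fluorine

The source may hold more compounds than are shown below. What is called first, only, known or untested is meant among the compounds shown, and "the series" means these compounds.

Compound 1 `COc1cccc(/C=C/C(=O)Nc2cc(C(=O)c3cc(OC)c(OC)c(OC)c3)ccc2OC)c1` gives 3100 nM in a functional assay on HeLa cells (Homo sapiens) for cytotoxicity, read by MTT assay, with a stated time of 72 h; on this read-out higher numbers stand for weaker inhibition and lower numbers for stronger inhibition. Compound 2 `COc1ccc(C(=O)c2cc(OC)c(OC)c(OC)c2)cc1NC(=O)/C=C/c1cccc(OC(F)(F)F)c1` gives 7900 nM in this assay, and the step of a 2.5-fold higher number from compound 1 to compound 2 (0.41 log units; beyond the scatter) shows that change. Compound 3 `COc1ccc(/C=C/C(=O)Nc2cc(C(=O)c3cc(OC)c(OC)c(OC)c3)cc(OC)c2OC)cc1OC` gives 2700 nM in this assay, a number within the scatter of compound 1 but beyond it, on the lower side, against compound 2. Compound 4 `COc1cc(C(=O)c2cc(OC)c(OC)c(OC)c2)cc(NC(=O)/C=C/c2ccc(F)cc2)c1OC` differs from compound 3 by 4-fluorophenyl in place of 3,4-dimethoxyphenyl on a double-bonded chain carbon bound to a double-bonded chain carbon. Among the measured compounds shown here, no measured step covers this swap; the only measured step concerns a different group and was modest. A modest step in this assay, likely toward a higher number, is therefore expected, though none beyond the scatter is also possible. Compound 4 is estimated at 4500 nM, between 1500 nM and 13000 nM. That estimate means an expected step of a 1.7-fold higher number from compound 3 to compound 4 (0.22 log units; within the scatter).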

Compound 4, half-maximal inhibitory concentration: 900 nM
Compound 4: middle estimate off by 5.0-fold (0.70 log units), on the high side; measured number outside the range, below it.
By their numbers in this assay, from the lowest: compound 4; then compounds 3 and 1 (each within the scatter of the next); then compound 2.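

Putting 4-fluorophenyl in place of 3,4-dimethoxyphenyl on a double-bonded chain carbon bound to a double-bonded chain carbon gives a 3.0-fold lower number from compound 3 to compound 4 (0.48 log units; beyond the scatter) in this assay. This is the first change shown to lower the number, whereas the only earlier step, a 2.5-fold higher number from compound 1 to compound 2 (0.41 log units; beyond the scatter), raised it. Nothing available here explains the drop. From the compounds shown here alone, whether the gain comes from adding fluorine or from losing the two methoxy groups stays open. Plain phenyl, 4-chlorophenyl or 4-aminophenyl in the same place would help separate these.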